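The source may report more compounds than this note shows. Statements on the series, on what has been measured and on what is new or still open speak of the compounds shown alone.

The account concerns a small set of agonists tested in a functional assay on CHO cells for agonist activity at Free fatty acid receptor 1 (Homo sapiens), read by FLIPR and calcium flux; a higher number here means that more compound is needed for the effect, a lower number that less compound is needed. Among the compounds with values here, compound 1, with the structure `Cc1nc(-c2ccsc2)sc1COc1ccc2c(c1)OCC2CC(=O)O`, is the only member of the set for which a number exists: in this assay compound 1 gives 68.5 nM. A second compound, compound 2 with the structure `Cc1nc(-c2ccccc2C(F)(F)F)sc1COc1ccc2c(c1)OCC2CC(=O)O`, belongs to the same set, but in this assay compound 2 is recorded only as "not determined" (no result reported), so it offers nothing to compare against. Compound 1 therefore stands alone on the numbers shown.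

The step of interest leads to compound 3, with the structure `Cc1nc(-c2ccc(C(F)(F)F)cc2)sc1COc1ccc2c(c1)OCC2CC(=O)O`, which has not yet been measured. The change from compound 1 is 4-(trifluoromethyl)phenyl in place of thiophen-3-yl on an aromatic carbon. Within the data shown here, no step between two measured compounds is available to guide the size of the effect, so the expectation rests on compound 1 alone. The change is expected to move the value by a 1.5-fold lower number from compound 1 to compound 3 (0.18 log units; within the scatter), a shift toward a lower number that may well stay within the usual scatter. Compound 3 is therefore expected to give about 45 nM in this assay, within a range from 12 nM to 170 nM.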

Compound 3, half-maximal effective concentration: 96.7 nM
For compound 3 the middle estimate is 2.1-fold (0.33 log units) below the measured one, and the stated range covers the measured number.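

With compound 3, the set gains its first readable step at this position, the aromatic carbon next to the ring nitrogen and next to the ring sulfur: in this assay, the exchange gives a 1.4-fold higher number from compound 1 to compound 3 (0.15 log units; within the scatter). This position therefore takes 4-(trifluoromethyl)phenyl, with 10 heavy atoms and a six-membered aromatic ring of carbon only, in place of thiophen-3-yl, with 5 heavy atoms and a five-membered aromatic ring with 1 hetero atom, and the two compounds remain within the scatter of each other. No independent measurement bears on this result, so the step records the outcome of this exchange without explaining it.

A single step cannot show whether this tolerance extends to other groups at the position, such as an unsubstituted phenyl, a pyridine ring or a cyclohexyl ring. It also leaves open whether replacing the trifluoromethyl of compound 3 with a methoxy group, a nitrile or a chlorine atom would separate the resulting compound from compound 3 by more than the scatter.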